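The source may report more compounds than this note shows. Statements on the series, on what has been measured and on what is new or still open speak of the compounds shown alone.

Measured in a functional assay on SK-MEL-5 cells (Homo sapiens) for inhibition, read by sulforhodamine B assay, with a stated time of 48 h, tested at 10 uM; on this read-out higher numbers stand for more inhibition at the one concentration tested (going by the name of the read-out) and lower numbers for less inhibition:
compound 1 `O=Cc1ccc(-c2cn3ccnc3c(-c3ccc4ncn(C5CCCCC5)c4c3)n2)cc1` — 56.5%
compound 2 `CC(=O)c1ccc(-c2cn3ccnc3c(-c3ccc4ncn(C5CCCCC5)c4c3)n2)cc1` — 24.8%
compound 3 `Clc1ccc(-c2cn3ccnc3c(-c3ccc4ncn(C5CCCCC5)c4c3)n2)cc1` — 12.4%

Compound 1 stands highest of the three, and both steps away from it, a number 31.7 percentage points lower from compound 1 to compound 2 (beyond the scatter) and a number 44.1 percentage points lower from compound 1 to compound 3 (beyond the scatter), lie beyond the scatter. Compound 4 `c1csc(-c2cn3ccnc3c(-c3ccc4ncn(C5CCCCC5)c4c3)n2)c1` has not been measured; it differs from compound 1 by thiophen-2-yl in place of 4-formylphenyl on an aromatic carbon. The two measured steps from compound 1 bear on this change, since each of them also removes the formyl, and each was large: a number 31.7 percentage points lower from compound 1 to compound 2 (beyond the scatter) and a number 44.1 percentage points lower from compound 1 to compound 3 (beyond the scatter). A change that takes away the formyl is therefore expected to bring a large fall in this assay, a number 38.5 percentage points lower from compound 1 to compound 4 (beyond the scatter). Compound 4 is estimated at 18%, with a range from 5% to 40%.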

Compound 4, a percentage reported as inhibition, at one concentration (the size of the read-out at that concentration, not a potency): 8.05%
For compound 4 the middle estimate is 10 percentage points above the measured one; measured number inside the range.
By their numbers in this assay, from the lowest: compounds 4 and 3 (each within the scatter of the next); then compound 2; then compound 1.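

In this assay, the fall that comes with losing the formyl does not need a six-membered ring at this position, as thiophen-2-yl in place of 4-formylphenyl gives a number 48.5 percentage points lower from compound 1 to compound 4 (beyond the scatter). Thiophen-2-yl and 4-chlorophenyl cannot be told apart here, with a number 4.4 percentage points lower from compound 3 to compound 4 (within the scatter), whereas the change from 4-acetylphenyl gives a number 16.8 percentage points lower from compound 2 to compound 4 (beyond the scatter). No measurement shown explains these differences. From the compounds shown here alone, it remains open whether a formyl carried on the thiophen-2-yl ring would restore the higher number, and whether an amine or a carboxylic acid in place of the formyl on the phenyl ring would match it.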